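Trading the nitrile for a sulfur-bearing group

The source may report more compounds than this note shows. Statements on the series, on what has been measured and on what is new or still open speak of the compounds shown alone.

Two compounds share one core and differ only in the group on an aromatic carbon. Compound 1 `CC1(C)C=C(n2ccccc2=O)c2cc(C=O)ccc2O1` carries a formyl there, and in a functional assay (trachea) with Rattus norvegicus as the target (a lower number here means a less potent compound, a higher number a more potent compound, by a factor of ten per unit of this negative logarithm), compound 1 gives 6.14. Compound 2 `CC1(C)C=C(n2ccccc2=O)c2cc(C#N)ccc2O1` carries a cyano in its place, and in this assay compound 2 gives 7.1, the higher of the two numbers; the step of a number 0.96 log units higher from compound 1 to compound 2 (beyond the scatter) lies beyond the scatter. Within the data shown here, compound 3 `CC1(C)C=C(n2ccccc2=O)c2cc(C(=N)S)ccc2O1` is not yet measured. a group of 3 heavy atoms (1 carbon, 1 nitrogen, 1 sulfur; no ring) in place of a group of 2 heavy atoms (1 carbon, 1 nitrogen; no ring), on an aromatic carbon The only step measured so far, a number 0.96 log units higher from compound 1 to compound 2 (beyond the scatter), concerns the same aromatic carbon but a different exchange, and no compound bearing a group of 1 carbon, 1 nitrogen and 1 sulfur has a number in this assay. That single step shows the position tolerates a change of group with a modest shift, so a shift of similar size in either direction is plausible; as compound 2 already stands at 7.1, the highest number seen, a move back toward the level of compound 1 seems more likely than a further rise. Compound 3 is therefore expected to give 6.3 in this assay, between 5.5 and 7.2. This estimate corresponds to an expected step of a number 0.80 log units lower from compound 2 to compound 3 (beyond the scatter).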

Compound 3, logarithm of the reciprocal of the active concentration, log(1/C): 5.96
Estimate against measurement, compound 3: 0.34 log units above, within the range that was stated.
By their numbers in this assay, from the lowest: compounds 3 and 1 (each within the scatter of the next); then compound 2.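

At this aromatic carbon, replacing the cyano with the group of 3 heavy atoms (1 carbon, 1 nitrogen, 1 sulfur) gives in this assay a number 1.14 log units lower from compound 2 to compound 3 (beyond the scatter) and so takes away most of what the cyano had gained over the formyl. Set against the formyl, the same group gives a number 0.18 log units lower from compound 1 to compound 3 (within the scatter) and cannot be told apart from it, so two different groups now stand at one level, and compound 2 alone stands clear, with its steps to both others beyond the scatter. Nothing measured here accounts for this separation of the cyano from the other two groups. On these data alone, whether any other group at this aromatic carbon can match the cyano remains open, for instance a carboxylic acid, an amine, a primary amide or a halogen such as chlorine. As far as these compounds go, all three compounds also share one core and one read-out, so it remains open whether the gap between the cyano and the other two groups would hold on a different core or in a different test.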